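The source may hold more compounds than are shown below. What is called first, only, known or untested is meant among the compounds shown, and "the series" means these compounds.

Measured so far:
compound 1 `N#Cc1c(Cl)cccc1OC[C@H](O)CN1CCC(Cc2ccccc2)CC1`: 2200 nM
compound 2 `COc1ccc(CC2CCN(C[C@@H](O)COc3cccc(Cl)c3C#N)CC2)cc1`: > 30000 nM, a limit of the assay
compound 3 `COc1cccc(CC2CCN(C[C@@H](O)COc3cccc(Cl)c3C#N)CC2)c1`: 640 nM

In a functional assay on HEK293 cells (Homo sapiens) for inhibition, read by FLIPR (on this read-out higher numbers stand for weaker inhibition and lower numbers for stronger inhibition), compound 3 gives 640 nM, the lowest number of the three. Next is compound 4 `N#Cc1c(Cl)cccc1OC[C@H](O)CN1CCC(Cc2cc(F)ccc2F)CC1`, with the change 2,5-difluorophenyl in place of 3-methoxyphenyl on a saturated chain carbon bound to a saturated ring carbon. The methoxy steps bear on this. One is modest, a 3.4-fold lower number from compound 1 to compound 3 (0.54 log units; beyond the scatter). Another is large, an at least 13-fold higher number from compound 1 to compound 2 (1.13 log units; beyond the scatter). The swap of 4-methoxyphenyl for 3-methoxyphenyl is also large, an at least 46-fold lower number from compound 2 to compound 3 (1.67 log units; beyond the scatter). Among the compounds with values here, no fluorine step has been measured. Compound 4 lacks the methoxy behind a 3.4-fold lower number from compound 1 to compound 3 (0.54 log units; beyond the scatter), so a modest move to a higher number is expected. The estimated step is a 2.0-fold higher number from compound 3 to compound 4 (0.31 log units; beyond the scatter). For compound 4 the expected value is 1300 nM, with an estimated range from 300 nM to 6000 nM.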

Compound 4, half-maximal inhibitory concentration: 2100 nM
Estimate against measurement, compound 4: 1.6-fold (0.21 log units) below, and the stated range covers the measured number.
By their numbers in this assay, from the lowest: compound 3; then compounds 4 and 1 (each within the scatter of the next). At a limit, above all of these: compound 2.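

In this assay, 2,5-difluorophenyl on this saturated chain carbon does not match 3-methoxyphenyl, with a 3.3-fold higher number from compound 3 to compound 4 (0.52 log units; beyond the scatter). The 2,5-difluorophenyl and phenyl groups cannot be told apart at this place, with a 1.0-fold lower number from compound 1 to compound 4 (0.02 log units; within the scatter). Substitution on this ring is therefore not uniformly costly: 2,5-difluorophenyl stands well clear of 4-methoxyphenyl, with an at least 14-fold lower number from compound 2 to compound 4 (1.15 log units; beyond the scatter), a step read against a limit: the limit of > 30000 nM in this assay, at which 1 of the 4 values shown sits. As far as these compounds go, how a chlorine, a hydroxyl or an amine on this ring would read remains open. So does the effect of a longer chain in place of the benzyl link.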